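This account rests on a few compounds, and the source may have more. Where it says the series, first, only, none or still open, it means among the compounds named here.

Of the compounds shown here, three built on one shared core have been measured in an assay on cells for activation of Cystic fibrosis transmembrane conductance regulator (Homo sapiens), read by fluorescence, with stated times of 10 min and 12 s; on this read-out lower numbers stand for an effect already at smaller amounts and higher numbers for an effect only at larger amounts of compound. Compound 1 `CCN(CC)c1nc(Nc2cccc(C(=O)O)c2)nc(OC(C(F)(F)F)C(F)(F)F)n1` gives 160 nM. Compound 2 `CCN(CC)c1nc(Nc2ccc(C(=O)O)cc2)nc(OC(C(F)(F)F)C(F)(F)F)n1` gives 900 nM, and compound 3 `CCN(CC)c1nc(Nc2ccc3cn[nH]c3c2)nc(OC(C(F)(F)F)C(F)(F)F)n1` gives 900 nM. Compound 2 thus stands level with compound 3, the two together at the high end of the three numbers, while a 5.6-fold higher number from compound 1 to compound 2 (0.75 log units; beyond the scatter) and a 5.6-fold higher number from compound 1 to compound 3 (0.75 log units; beyond the scatter) set compound 1 apart. Compound 4 `CCN(CC)c1nc(Nc2ccc3ncsc3c2)nc(OC(C(F)(F)F)C(F)(F)F)n1` differs from compound 2 by 1,3-benzothiazol-6-yl in place of 4-carboxyphenyl on a nitrogen on an aromatic ring. The step that bears most directly on this is no change at the digits printed from compound 2 to compound 3 (within the scatter), where a different group replaced the same carboxyphenyl without effect. For compound 4 the expectation is therefore a 1.1-fold higher number from compound 2 to compound 4 (0.05 log units; within the scatter). Compound 4 is expected to give about 1000 nM in this assay, within a range from 400 nM to 2500 nM.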

Compound 4, half-maximal effective concentration: 50 nM
Compound 4: middle estimate off by 20-fold (1.30 log units), on the high side; the measured number lies below the stated range.
By their numbers in this assay, from the lowest: compound 4; then compound 1; then compounds 2 and 3 (each within the scatter of the next).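

Replacing the acid-bearing ring is not in itself costly at this position on the nitrogen: 1,3-benzothiazol-6-yl, which has no hydrogen-bond donor, gives an 18-fold lower number from compound 2 to compound 4 (1.26 log units; beyond the scatter) and a 3.2-fold lower number from compound 1 to compound 4 (0.51 log units; beyond the scatter). A two-ring group as such does not account for this, since exchanging 1H-indazol-6-yl for it gives an 18-fold lower number from compound 3 to compound 4 (1.26 log units; beyond the scatter). Nothing measured here gives the reason for these steps.

On these data alone, it remains open whether the sulfur matters, as 1,3-benzoxazol-6-yl, with oxygen in its place, would test. Also open, as far as these compounds go, is whether a carboxylic acid or an amine on 1,3-benzothiazol-6-yl would keep the number low.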